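The source may hold more compounds than are shown below. What is called first, only, known or untested is meant among the compounds shown, and "the series" means these compounds.

Series notes on the shared core. Compound 1 `O=S(=O)(Nc1ccc(-c2nc3ccccc3o2)cc1)c1cccc(F)c1` in an assay on cells for inhibition of HSP60/HSP10 (Homo sapiens), with a stated time of 60 min (a lower number here means a stronger inhibitor, a higher number a weaker inhibitor), gives 71000 nM, and compound 2 `O=S(=O)(Nc1ccc(-c2nc3ccccc3o2)cc1)c1cccc(O)c1` gives 62000 nM, the step of a 1.1-fold lower number from compound 1 to compound 2 (0.06 log units; within the scatter). Compound 3 `CS(=O)(=O)Nc1ccc(-c2nc3ccccc3o2)cc1` carries a methyl on the sulfonyl sulfur; for compound 3 this assay reports only a limit, > 100000 nM (the limit of > 100000 nM in this assay, at which 1 of the 3 values shown sits). The steps of an at least 1.4-fold higher number from compound 1 to compound 3 (0.14 log units; that floor lies within the scatter) and an at least 1.6-fold higher number from compound 2 to compound 3 (0.20 log units; that floor lies within the scatter) are the only ones that touch the sulfonyl substituent, and both floors lie within the scatter. Compound 4 `COc1ccccc1S(=O)(=O)Nc1ccc(-c2nc3ccccc3o2)cc1` differs from compound 3 by 2-methoxyphenyl in place of methyl on a sulfonyl sulfur, again an aryl group on the sulfonyl sulfur as in compounds 1 and 2. The expected step is therefore an at least 1.4-fold lower number from compound 3 to compound 4 (0.15 log units; that floor lies within the scatter), toward the numbers seen for compounds 1 and 2, with a limit still possible. For compound 4 in this assay the estimate is 70000 nM, with a range from 30000 nM to 160000 nM.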

Compound 4, half-maximal inhibitory concentration: > 100000 nM
Compound 4: no number, only a limit; the forecaster's own chance of this, stated with the estimate: 30%; at least 1.4-fold (0.15 log units) between middle value and limit.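

In this assay compound 4 gives a limit and not a number, like compound 3, so an aryl group on the sulfonyl sulfur does not by itself yield a number: the limit of > 100000 nM in this assay, at which 2 of the 4 values shown sit. The readable steps, an at least 1.6-fold higher number from compound 2 to compound 4 (0.20 log units; that floor lies within the scatter) and an at least 1.4-fold higher number from compound 1 to compound 4 (0.14 log units; that floor lies within the scatter), have floors within the scatter, so they do not separate 2-methoxyphenyl from 3-hydroxyphenyl or 3-fluorophenyl. The step between the two limits cannot be read. Open, going by these compounds, is whether an amine or a carboxylic acid on the aryl ring would give a step beyond the scatter from compound 1 or compound 2.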